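Cytotoxicity of a Thiadiazole Amide Series: Expecting Compound 4

This account rests on a few compounds, and the source may have more. Where it says the series, first, only, none or still open, it means among the compounds named here.

Compound 3 `Cc1cccc(NC(=O)CSc2snnc2-c2ccc(Br)cc2Br)c1C` stands highest of the two numbers in hand in an ADME assay on MT4 cells (Homo sapiens) for cytotoxicity, read by MTT assay, with a stated time of 5 days (a lower number here means that less compound is tolerated, a higher number that more compound is tolerated), where compound 3 gives 241000 nM. Its nearest neighbour is compound 2 `Cc1ccccc1NC(=O)CSc1snnc1-c1ccc(Br)cc1Br`, which in this assay gives 202000 nM; the step of a 1.2-fold higher number from compound 2 to compound 3 (0.08 log units; within the scatter) lies within the scatter. Compound 1 `O=C(CSc1snnc1-c1ccc(Br)cc1Br)Nc1ccccc1[N+](=O)[O-]` reaches only a limit of the assay in this assay, reported as > 235000 nM. Because the limit of > 235000 nM in this assay, at which 1 of the 3 values shown sits, caps that value, the step that the limit leaves unreadable from compound 1 to compound 3 cannot be sized, and an at least 1.1-fold lower number from compound 1 to compound 2 (0.06 log units; that floor lies within the scatter) carries only a floor.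

Compound 4 `COC(=O)c1ccsc1NC(=O)CSc1snnc1-c1ccc(Br)cc1Br` differs from compound 3 in one place: 3-(methoxycarbonyl)thiophen-2-yl in place of 2,3-dimethylphenyl on an amide-type nitrogen. All three measured steps likewise exchange the group on the amide-type nitrogen, and none of them shows a change beyond the scatter, whether from a nitrophenyl to a methylphenyl or from one methylphenyl to a dimethylphenyl. For the measured compounds named here, the new group is a heteroaryl carrying a methoxycarbonyl, which none of the measured compounds shares, so the exchange reaches further than any step already measured. Still, with every measured value sitting near the top of the assay window, the expectation for compound 4 in this assay is no step beyond the scatter. Compound 4 is therefore estimated at 220000 nM, in a range from 110000 nM to 300000 nM, corresponding to an expected step of a 1.1-fold lower number from compound 3 to compound 4 (0.04 log units; within the scatter).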

Compound 4, half-maximal cytotoxic concentration: > 227000 nM
Compound 4: a limit, no number (the forecaster's own chance of this, stated with the estimate: 30%); at least 1.0-fold (0.01 log units) between middle value and limit.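

The exchange on the amide-type nitrogen brings in a five-membered aromatic ring with a hetero atom and a methoxycarbonyl, and in this assay compound 4 still ends at a limit of the assay, > 227000 nM, rather than at a readable number. For the compounds shown here, the only step that can be read is an at least 1.1-fold higher number from compound 2 to compound 4 (0.05 log units; that floor lies within the scatter), which is a floor and so shows no change beyond the scatter while leaving the true size open. Because of the limit on compound 4, its steps to compound 3 and compound 1 cannot be read: the limit of > 227000 nM in this assay, at which 1 of the 4 values shown sits.

All four compounds shown keep the shared core and vary only the group on the amide-type nitrogen, so they leave open whether any group there would bring the number in this assay clearly down from the top of the assay window. Also open, as far as these compounds go, is what a carboxylic acid or an amine in place of the methoxycarbonyl on the thiophene would do, and how far compound 4 really lies from its neighbours.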